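Terminal chain group: piperidinylmethyl against phenyl

The source may report more compounds than this note shows. Statements on the series, on what has been measured and on what is new or still open speak of the compounds shown alone.

Compound 1 `CCCCCCCCCCCCCCCC(=O)Nc1c(C)cc(C)c2c1OC(C)(C)C2` carries a long unbranched acyl chain on the shared core and in an assay for inhibition of acyl-CoA:cholesterol acyltransferase (Oryctolagus cuniculus), using microsomes (a lower number here means a stronger inhibitor, a higher number a weaker inhibitor), compound 1 gives 26 nM. Compound 2 `Cc1cc(C)c(NC(=O)C(C)(C)CCCCCCN2CCCCC2)c2c1CC(C)(C)O2` keeps the same core but its acyl chain is shortened, branched next to the carbonyl, and ends in a piperidine. In this assay compound 2 gives > 500 nM, which is a limit of the assay and not a number. Compound 2 therefore stands at the limit of > 500 nM in this assay, at which 1 of the 2 values shown sits, and its distance to compound 1 cannot be measured from these two values beyond the fact that compound 1 has a number and compound 2 does not.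

Compound 3 `Cc1cc(C)c(NC(=O)C(C)(C)CCCCCc2ccccc2)c2c1CC(C)(C)O2` differs from compound 2 in one place: phenyl in place of (piperidin-1-yl)methyl on a saturated chain carbon, six bonds along the chain from a carbonyl carbon. Among the compounds with values here, no measured step of this kind is available, so the direction can only be expected, not read off. Because compound 1, with a chain of carbon only, gives 26 nM, a chain terminus of carbon only in compound 3 is expected to move the value back to a measurable number, and the step of an at least 4.1-fold lower number from compound 2 to compound 3 (0.61 log units; beyond the scatter) is expected as a gain. For compound 3 the estimate in this assay is 120 nM, with a range from 25 nM to 500 nM.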

Compound 3, half-maximal inhibitory concentration: 120 nM
The estimate for compound 3 equals the measured number at the digits printed; measured number inside the range.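

In this assay, within the data shown here, phenyl in place of (piperidin-1-yl)methyl on a saturated chain carbon, six bonds along the chain from a carbonyl carbon, gives an at least 4.1-fold lower number from compound 2 to compound 3 (0.61 log units; beyond the scatter), the first step between compounds that differ in one place. Compound 2 gives > 500 nM, which is a limit of the assay and not a number, so the step has a known lower bound but no known size, and its position in the series is: the limit of > 500 nM in this assay, at which 1 of the 3 values shown sits. The group at this chain end therefore matters in this assay, and with phenyl there, compound 3 gives a measured value of 120 nM.

The single change swaps a non-aromatic ring holding a nitrogen for an aromatic ring of carbon only, so the compounds shown cannot separate the loss of the nitrogen from the gain of the aromatic ring, and a cyclohexylmethyl group at the same place would bear on that question. From the compounds shown here alone, how the value responds to a longer chain before the phenyl, or to a carboxylic acid at the chain end, remains open.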